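This account rests on a few compounds, and the source may have more. Where it says the series, first, only, none or still open, it means among the compounds named here.

Working notes on the series. For the measured compounds named here, in a functional assay on cells (Cancer cell lines, Homo sapiens) for inhibition (on this read-out higher numbers stand for weaker inhibition of growth and lower numbers for stronger inhibition of growth), compound 2 (`N=C(N)N/N=C/c1c(-c2ccsc2)nc2n1CCS2`) gives 22900 nM, the highest of the two numbers so far, and compound 1 (`N=C(N)N/N=C/c1c(-c2cc(Cl)sc2Cl)nc2n1CCS2`) gives 1820 nM. Compound 3 (`Cc1cc(-c2nc3n(c2/C=N/NC(=N)N)CCS3)c(C)s1`) differs from compound 2 by one change: 2,5-dimethylthiophen-3-yl in place of thiophen-3-yl on an aromatic carbon. Going by the values given here, the only measured step that bears on it is a 13-fold higher number from compound 1 to compound 2 (1.10 log units; beyond the scatter), which is large and beyond the scatter. Among the compounds with values here, no dimethyl analogue has been measured, so that step serves only as a rough guide. A smaller step to a lower number is expected in this assay: the estimated step is a 3.8-fold lower number from compound 2 to compound 3 (0.58 log units; beyond the scatter). The estimate for compound 3 is 6000 nM, with an expected range of 1800 nM to 18000 nM.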

Compound 3, concentration for 50% growth inhibition: 13800 nM
The estimate for compound 3 lay 2.3-fold (0.36 log units) below the measured number; the range from low to high includes it.
By their numbers in this assay, from the lowest: compound 1; then compounds 3 and 2 (each within the scatter of the next).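

In this assay, 2,5-dimethylthiophen-3-yl in place of thiophen-3-yl gives a 1.7-fold lower number from compound 2 to compound 3 (0.22 log units; within the scatter) and so does not separate the two compounds at this position on the shared core. Against the dichloro compound, the same group gives a 7.6-fold higher number from compound 1 to compound 3 (0.88 log units; beyond the scatter) and so leaves 2,5-dichlorothiophen-3-yl as the only substituent of the three that stands apart. No evidence available here explains this difference.

Still open, going by these compounds, is whether compound 1 needs both chlorines, and how an amine or a carboxylic acid on the thiophene would read out.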